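Trimming the Sulfonamide: From Compound 3 to Compound 4

This account rests on a few compounds, and the source may have more. Where it says the series, first, only, none or still open, it means among the compounds named here.

Measured compounds:
compound 1 `CCCCc1ccc(CNC(=O)Nc2ccccc2)c(=O)n1Cc1ccc(-c2ccccc2-c2nn[nH]n2)cc1` — 30 nM
compound 2 `CCCCc1ccc(CNC(=O)N(C)C)c(=O)n1Cc1ccc(-c2ccccc2-c2nn[nH]n2)cc1` — 2 nM
compound 3 `CCCCc1ccc(CN(C)S(=O)(=O)c2ccc(C)cc2)c(=O)n1Cc1ccc(-c2ccccc2-c2nn[nH]n2)cc1` — 8 nM

All three were tested in a functional assay (aorta) for antagonist activity, with Oryctolagus cuniculus as the target; on this read-out higher numbers stand for weaker inhibition and lower numbers for stronger inhibition. Compound 3 stands second highest of the three numbers: the step of a 3.8-fold lower number from compound 1 to compound 3 (0.57 log units; beyond the scatter) places it below compound 1, while a 4.0-fold higher number from compound 2 to compound 3 (0.60 log units; beyond the scatter) places it above compound 2, both beyond the scatter.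

Compound 4 `CCCCc1ccc(CN(C(C)C)S(C)(=O)=O)c(=O)n1Cc1ccc(-c2ccccc2-c2nn[nH]n2)cc1` differs from compound 3 in one place: isopropyl(methylsulfonyl)amino in place of methyl((4-methylphenyl)sulfonyl)amino on a saturated chain carbon bound to an aromatic carbon. Among the measured compounds shown here, no measured step makes exactly this change. The closest guide is a 15-fold lower number from compound 1 to compound 2 (1.18 log units; beyond the scatter), where a group carrying a six-membered aromatic ring of carbon only gave way to a smaller group with no ring, a large step. The change from compound 3 to compound 4 likewise replaces a ring-bearing group with one having no ring, though it also exchanges methyl for isopropyl within the group, and for that exchange nothing has been measured. Compound 4 is therefore expected to give a somewhat lower number than compound 3, a modest step of a 2.0-fold lower number from compound 3 to compound 4 (0.30 log units; within the scatter). The estimate for compound 4 in this assay is 4 nM, with a range from 1 nM to 15 nM.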

Compound 4, half-maximal inhibitory concentration: 0.9 nM
Compound 4: middle estimate off by 4.4-fold (0.65 log units), on the high side; the whole stated range lies above it.
By their numbers in this assay, from the lowest: compound 4; then compound 2; then compound 3; then compound 1.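

In this assay, the step to the isopropyl(methylsulfonyl)amino group gives an 8.9-fold lower number from compound 3 to compound 4 (0.95 log units; beyond the scatter), which shows that on this saturated chain carbon bound to an aromatic carbon, a sulfonyl-bearing group can lose its six-membered aromatic ring of carbon only and still give a lower number. The result also puts a ring-free sulfonyl group ahead of both carbamoyl groups, with a 2.2-fold lower number from compound 2 to compound 4 (0.35 log units; beyond the scatter) and a 33-fold lower number from compound 1 to compound 4 (1.52 log units; beyond the scatter), so compound 4 has the lowest number of the four in this assay. No evidence at hand accounts for the size of these steps.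

Because this change exchanges the group on the sulfur and the group on the nitrogen at once, the compounds shown leave open how much of the step belongs to each, a question that methyl(methylsulfonyl)amino or isopropyl((4-methylphenyl)sulfonyl)amino would address. They also leave open whether the number falls further or rises with a cyclopropyl or tert-butyl group on the nitrogen, or with a longer chain such as butyl on the sulfur.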